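The compounds below may be only part of what the source reports. "The series", "measured", "known", "first", "only" and "open" are said of these compounds alone.

The three measured compounds share a core and differ only at two points. Compound 1 `CCc1ccc2nc(C(=O)Nc3c(F)cc(-c4cccc(F)c4)cc3F)c(C)c(O)c2c1` gives -0.35% in a functional assay on A-375 cells (Homo sapiens) for antiproliferative activity, read by MTT assay, with a stated time of 24 h, tested at 0.01 ug/mL; a higher number here means a stronger effect of the compound at the concentration tested, a lower number a weaker effect. Compound 2 `CCOc1ccc2nc(C(=O)Nc3c(F)cc(-c4cccc(F)c4)cc3F)c(C)c(O)c2c1` gives 0.23%, and compound 3 `CCc1ccc2nc(C(=O)Nc3c(F)cc(-c4cccc(F)c4)cc3F)c(C)c(C(=O)O)c2c1` gives -0.45%. Among the compounds with values here, the move a number 0.6 percentage points higher from compound 1 to compound 2 (within the scatter) and the move a number 0.1 percentage points lower from compound 1 to compound 3 (within the scatter) both stay within the scatter, so compound 3 stands within the scatter of compound 1 and of compound 2 alike; no compound can be called stronger or weaker here.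

Compound 4 `CCOc1ccc2nc(C(=O)Nc3c(F)cc(-c4cccc(F)c4)cc3F)c(C)c(C(=O)O)c2c1` is reached from compound 3 by the change (ethoxy in place of ethyl on an aromatic carbon). The same change has been measured once, from compound 1 to compound 2, and there it gave a number 0.6 percentage points higher from compound 1 to compound 2 (within the scatter), a step within the scatter. On that single precedent, compound 4 is expected to show no step beyond the scatter, with an expected change of a number 0.6 percentage points higher from compound 3 to compound 4 (within the scatter). Compound 4 is therefore estimated at 0.1%, with a range from -6% to 6%.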

Compound 4, a percentage reported as inhibition, at one concentration (the size of the read-out at that concentration, not a potency): 0.3%
Compound 4: middle estimate off by 0.2 percentage points, on the low side; the measured number falls inside the stated range.
By their numbers in this assay, from the lowest: compounds 3, 1, 2 and 4 (each within the scatter of the next).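

The change of ethoxy in place of ethyl now has a second reading, on the core that carries carboxy instead of hydroxy, where a number 0.8 percentage points higher from compound 3 to compound 4 (within the scatter) again stays small: the same change on two cores in this assay, a number 0.6 percentage points higher (within the scatter) from compound 1 to compound 2 and a number 0.8 percentage points higher (within the scatter) from compound 3 to compound 4, 0.2 percentage points apart, within the scatter of two such steps. The change of carboxy in place of hydroxy also gains a second reading, on the ethoxy core, where a number 0.1 percentage points higher from compound 2 to compound 4 (within the scatter) matches its first reading: the same change on two cores in this assay, a number 0.1 percentage points lower (within the scatter) from compound 1 to compound 3 and a number 0.1 percentage points higher (within the scatter) from compound 2 to compound 4, 0.2 percentage points apart, within the scatter of two such steps. With both changes read on two cores, all four steps among these compounds stay within the scatter, and neither change shows any dependence on the other.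

All four values lie close to zero at the single concentration tested, so these compounds cannot tell whether either change would matter where the read-out is larger. From the compounds shown here alone, what an amine in place of the hydroxy or carboxy group, or a longer chain such as propoxy in place of ethoxy, would give in this assay remains open.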